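This account rests on a few compounds, and the source may have more. Where it says the series, first, only, none or still open, it means among the compounds named here.

Measured so far in an assay on isolated protein for inhibition of alpha-ketoglutarate-dependent dioxygenase alkB homolog 3 (Homo sapiens), read by fluorescence, with stated times of 60 min and 15 min; a lower number here means a stronger inhibitor, a higher number a weaker inhibitor:
compound 1 `COc1ccc(C2=C(Br)C(=O)c3ccc(C)cc32)cc1` gives 43200 nM;
compound 2 `COc1ccc(C2=C(Cl)C(=O)c3ccc(C)cc32)cc1` gives > 50000 nM.

For compound 2 that value is a limit of this assay, not a measured number (the limit of > 50000 nM in this assay, at which 1 of the 2 values shown sits). Compound 3 `COc1ccc(C2=C(Cl)C(=O)c3ccc(-c4ccccc4)cc32)cc1` differs from compound 2 by phenyl in place of methyl on an aromatic carbon. Going by the values given here, the only measured step, an at least 1.1-fold higher number from compound 1 to compound 2 (0.06 log units; that floor lies within the scatter), swaps one halogen for another and says nothing about a phenyl in place of methyl, so no measured step bears on this change. The expected step is therefore an at least 1.2-fold lower number from compound 2 to compound 3 (0.09 log units; that floor lies within the scatter), with no direction beyond the scatter. Compound 3 is estimated at 40000 nM, expected between 8000 nM and 200000 nM.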

Compound 3, half-maximal inhibitory concentration: > 50000 nM
Compound 3 gave a limit, no number (the forecaster's own chance of this, stated with the estimate: 50%); at least 1.2-fold (0.09 log units) between middle value and limit.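

Compound 2 and compound 3 both give a limit rather than a number, so no step can be read between them: the limit of > 50000 nM in this assay, at which 2 of the 3 values shown sit.

The compounds shown leave open whether phenyl in place of methyl on an aromatic carbon changes inhibition at all, and in which direction.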